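Methyl for chloro on the phenyl ring

The source may report more compounds than this note shows. Statements on the series, on what has been measured and on what is new or still open speak of the compounds shown alone.

Two members of the series have been measured in an assay on membranes from liver for displacement of a labelled ligand from Sigma non-opioid intracellular receptor 1 (Rattus norvegicus), read by scintillation counting; a lower number here means a stronger inhibitor, a higher number a weaker inhibitor. Compound 1 `CN(CCCn1c(=O)oc2ccccc21)Cc1cccc(Cl)c1` gives 3230 nM. Compound 2 `CN(CCCn1c(=O)oc2ccccc21)Cc1ccc(Cl)cc1` gives 1150 nM. Among the measured compounds shown here, the single step between them, a 2.8-fold lower number from compound 1 to compound 2 (0.45 log units; beyond the scatter), moves the chloro substituent from one aromatic carbon to another without changing what the group is. For the measured compounds named here, on these two numbers compound 2 holds the lower value, with compound 1 as its only neighbour at the higher figure.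

Compound 3 `Cc1ccc(CN(C)CCCn2c(=O)oc3ccccc32)cc1` keeps the 4-substituted pattern of compound 2 and differs from it by methyl in place of chloro on an aromatic carbon. Going by the values given here, no measured step exchanges one group for another on this ring; the only step known, from compound 1 to compound 2, concerns where a chloro sits and so bears on the present change only loosely, showing that this position of the ring is sensitive at a modest level. With nothing to set the size of a chloro-to-methyl exchange, the expectation is a step no larger than the scatter, with a slight lean toward a higher number. Compound 3 is therefore expected to give about 1600 nM, within a range of 600 nM to 4500 nM. That estimate corresponds to an expected step of a 1.4-fold higher number from compound 2 to compound 3 (0.14 log units; within the scatter).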

Compound 3, inhibition constant: 871 nM
Estimate against measurement, compound 3: 1.8-fold (0.26 log units) above, and the stated range covers the measured number.
By their numbers in this assay, from the lowest: compounds 3 and 2 (each within the scatter of the next); then compound 1.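

In this assay, among the compounds shown here, the exchange of chloro for methyl, on an aromatic carbon para to a large group, gives a 1.3-fold lower number from compound 2 to compound 3 (0.12 log units; within the scatter) and is the first reading of a change of group on this ring rather than a change of where a chloro sits; on this pair the two groups cannot be told apart. The step of a 3.7-fold lower number from compound 1 to compound 3 (0.57 log units; beyond the scatter) is beyond the scatter and modest, and together with a 2.8-fold lower number from compound 1 to compound 2 (0.45 log units; beyond the scatter) it places both 4-chlorophenyl and 4-methylphenyl at lower numbers than 3-chlorophenyl, with no compound shown going against this. Nothing measured alongside these numbers accounts for either the close match or the gap to compound 1.

Going by these compounds, whether the match between chloro and methyl holds for other groups at this place remains open, for instance methoxy, trifluoromethyl, an amine or a carboxylic acid, as does the reading of the plain phenyl with hydrogen there. On these data alone, it is also open whether 3-methylphenyl would follow 3-chlorophenyl, which would show if the match extends to the other ring position.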